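This account rests on a few compounds, and the source may have more. Where it says the series, first, only, none or still open, it means among the compounds named here.

Measured compounds:
compound 1 `CCCCCCn1ccc2cc(/C(C)=C/C(=O)Nc3ccccc3OCCCC(=O)O)ccc21` — 77 nM
compound 2 `CCCCC(CC)n1ccc2cc(/C(C)=C/C(=O)Nc3ccccc3OCCCC(=O)O)ccc21` — 7.1 nM

Among the measured compounds shown here, in an assay on Prostate gland for inhibition of steroid 5-alpha-reductase (Rattus norvegicus) (on this read-out lower numbers stand for stronger inhibition and higher numbers for weaker inhibition), compound 1 gives 77 nM, the highest of the two numbers so far; its nearest neighbour is compound 2, which gives 7.1 nM. For the measured compounds named here, the one step measured so far, an 11-fold lower number from compound 1 to compound 2 (1.04 log units; beyond the scatter), replaces the hexyl group with 1-ethylpentyl at the same position.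

Compound 3 `C/C(=C\C(=O)Nc1ccccc1OCCCC(=O)O)c1ccc2c(ccn2C(C)c2ccccc2)c1` has not been measured. It differs from compound 1 at the same aromatic nitrogen: 1-phenylethyl in place of hexyl on an aromatic nitrogen. As in compound 2, the group entering is branched at the carbon that attaches to the nitrogen, but here the branch carries a six-membered aromatic ring of carbon only rather than a further alkyl chain, and the count of heavy atoms rises by two.

The step from compound 1 to compound 2 is the only one that bears on this change, and it was large. A lower number is therefore expected for compound 3 in this assay, though with less confidence than for compound 2, since no aromatic substituent at this nitrogen has yet been measured; the expected step is a 5.1-fold lower number from compound 1 to compound 3 (0.71 log units; beyond the scatter). Compound 3 is estimated at 15 nM, within a range of 4 nM to 60 nM.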

Compound 3, half-maximal inhibitory concentration: 19 nM
For compound 3 the middle estimate is 1.3-fold (0.10 log units) below the measured one; low and high end bracket the measured number.
By their numbers in this assay, from the lowest: compound 2; then compound 3; then compound 1.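

In this assay a six-membered aromatic ring on the branched carbon attached to the aromatic nitrogen still keeps the number clearly under that of the straight hexyl chain (a 4.1-fold lower number from compound 1 to compound 3 (0.61 log units; beyond the scatter)). The branch need not carry a further alkyl chain for a step of this direction, so among the three compounds both groups branched at that carbon lie below hexyl, and none goes against this. The ring does not reach the level of the alkyl branch, however (a 2.7-fold higher number from compound 2 to compound 3 (0.43 log units; beyond the scatter)), which leaves 1-ethylpentyl with the lowest number of the three groups at this position. Nothing at hand accounts for this order of the three groups on the nitrogen.

On these data alone, whether the ring or the branch carries the step from hexyl stays open: a benzyl group on the same nitrogen, with the ring but no branch, would separate the two, as would a 1-methylpentyl group on the alkyl side. Also open, as far as these compounds go, is how the number responds to a chlorine or a methoxy group on the phenyl ring of 1-phenylethyl, and whether the two mirror forms of that group differ.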